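The source may report more compounds than this note shows. Statements on the series, on what has been measured and on what is new or still open speak of the compounds shown alone.

In an in vitro functional assay on RBL cells for antagonist activity at C-C chemokine receptor type 8 (Homo sapiens), read by FLIPR and calcium flux (on this read-out higher numbers stand for weaker inhibition and lower numbers for stronger inhibition), compound 1 `O=C1OC(c2ccc3ccccc3n2)CN1C1CCN(Cc2cc3ccccc3[nH]2)CC1` gives < 50200 nM, which is a limit of the assay rather than a measured number. Compound 2 `COc1ccc2nccc(C3CN(C4CCN(Cc5c[nH]c6ccccc56)CC4)C(=O)O3)c2c1` likewise gives < 50200 nM in this assay, again only a limit. Compound 2 therefore stands at the limit of < 50200 nM in this assay, at which 2 of the 2 values shown sit, and nothing finer can be said about its place among the values shown. Compound 3 `COc1ccc2nccc(C3CN(C4CCN(CC5CCCCC5)CC4)C(=O)O3)c2c1` differs from compound 2 by cyclohexyl in place of 1H-indol-3-yl on a saturated chain carbon bound to an amine nitrogen in a ring. Among the measured compounds shown here, no step between measured compounds is available to show how such a change behaves here, so the step from compound 2 to compound 3 in this assay is expected to be a step that the limit leaves unreadable from compound 2 to compound 3, with no direction favoured beyond the scatter. Compound 3 is estimated to give about 5000 nM in this assay, with an expected range from 300 nM to 50000 nM.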

Compound 3, half-maximal inhibitory concentration: 7940 nM
For compound 3 the middle estimate is 1.6-fold (0.20 log units) below the measured one, and the stated range covers the measured number.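

Among the compounds shown here, no step from compound 2 to compound 3 can be read in this assay, because compound 2 has only a limit there: the limit of < 50200 nM in this assay, at which 2 of the 3 values shown sit.

The compounds shown leave open whether cyclohexyl in place of 1H-indol-3-yl strengthens or weakens inhibition, and by how much.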